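A few compounds are considered here, and "the series" means these few. Any claim that something is new, unique, unknown or untested is made for them only; others in the source may bear on it.

In a functional assay on PC-3 cells (Homo sapiens) for antiproliferative activity, read by MTT assay, with a stated time of 48 h (on this read-out lower numbers stand for stronger inhibition of growth and higher numbers for weaker inhibition of growth), three compounds sharing one core have been measured. Compound 1 (`Cc1ccc(OCCCN(Cc2ccc(C(=O)NO)cc2)c2ncc(-c3ccc(C)cc3)s2)cc1`) gives 9330 nM on this scale, compound 2 (`Cc1ccc(-c2cnc(N(CCCCOc3ccccc3)Cc3ccc(C(=O)NO)cc3)s2)cc1`) gives 10300 nM and compound 3 (`CCCCN(Cc1ccc(C(=O)NO)cc1)c1ncc(-c2ccc(C)cc2)s1`) gives 6410 nM on the same scale. Compound 3 stands within the scatter of both others, through the steps of a 1.5-fold lower number from compound 1 to compound 3 (0.16 log units; within the scatter) and a 1.6-fold lower number from compound 2 to compound 3 (0.21 log units; within the scatter) that reach it. The first puts methyl in place of 4-methylphenoxy, and the second puts hydrogen in place of phenoxy. The remaining step (a 1.1-fold higher number from compound 1 to compound 2 (0.04 log units; within the scatter)) also changes only this chain. Compound 4 (`CCCCCCN(Cc1ccc(C(=O)NO)cc1)c1ncc(-c2ccc(C)cc2)s1`) has ethyl in place of hydrogen on a saturated chain carbon, four bonds along the chain from a nitrogen on an aromatic ring. Going by the values given here, the closest precedent, at that same carbon, is the step of a 1.6-fold lower number from compound 2 to compound 3 (0.21 log units; within the scatter) and on that ground no step beyond the scatter is expected in this assay for this change. The estimated step (a 1.0-fold higher number from compound 3 to compound 4 (0.01 log units; within the scatter)) is accordingly small. For compound 4 the expected value is 6500 nM with an estimated range from 3000 nM to 13000 nM around it.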

Compound 4, concentration for 50% growth inhibition: 5270 nM
Estimate against measurement, compound 4: 1.2-fold (0.09 log units) above; measured number inside the range.
By their numbers in this assay, from the lowest: compounds 4, 3, 1 and 2 (each within the scatter of the next).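

In this assay, going by these compounds alone, ethyl in place of hydrogen at this chain carbon (a 1.2-fold lower number from compound 3 to compound 4 (0.09 log units; within the scatter)) shows that the plain alkyl chain can also be extended here without a step beyond the scatter, whereas the earlier steps only exchanged or removed the aryloxy ends. The two new comparisons with those aryloxy chains, ethyl in place of phenoxy (a 2.0-fold lower number from compound 2 to compound 4 (0.29 log units; within the scatter)) and propyl in place of 4-methylphenoxy (a 1.8-fold lower number from compound 1 to compound 4 (0.25 log units; within the scatter)), also stay within the scatter, so all four chains shown give values that cannot be told apart on this read-out. No evidence is available that bears on this result.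

The compounds shown leave open whether a chain ending in an amine or a carboxylic acid would give a step beyond the scatter. They also leave open whether a still longer alkyl chain would do so.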